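A few compounds are considered here, and "the series" means these few. Any claim that something is new, unique, unknown or untested is made for them only; others in the source may bear on it.

Working notes on the series, all read in a functional assay on SW480 cells (Homo sapiens) for antiproliferative activity, read by MTT assay, with a stated time of 48 h; on this read-out higher numbers stand for weaker inhibition and lower numbers for stronger inhibition. Here compound 1 (`CCCCCCC(CCO)n1cnc2c(N)ncnc21`) gives > 50000 nM as its result, and that result is a limit, not a number. Going by the values given here, compound 2 (`CCCCCCCCCC(CCO)n1cnc2c(OC)ncnc21`) gives 3250 nM as the only true number so far, so its standing cannot be stated against another measured value. Compound 3 (`CCCCCCCCCC(CCO)n1cnc2c(N)ncnc21`) has not yet been measured. The step to it puts amino in place of methoxy on an aromatic carbon. Among the compounds with values here, no measured pair isolates this exchange, so there is no direct precedent for its size. With compound 2 at 3250 nM as the sole anchor, a moderate move towards weaker inhibition is expected, only a little beyond the usual scatter, and a smaller change would not be surprising. The expected step is a 1.8-fold higher number from compound 2 to compound 3 (0.27 log units; within the scatter) on this estimate. For compound 3 the estimated value is 6000 nM with 1800 nM to 25000 nM as the expected range.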

Compound 3, half-maximal inhibitory concentration: 6030 nM
For compound 3 the middle estimate is 1.0-fold (0.00 log units) below the measured one, within the range that was stated.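

In this assay, going by these compounds alone, the first measured pair at this aromatic carbon, opposite the ring nitrogen, puts amino in place of methoxy and gives a 1.9-fold higher number from compound 2 to compound 3 (0.27 log units; within the scatter), so the two groups cannot be told apart on this read-out while the chain of compound 3 is held fixed. The chain exchange, propyl in place of hydrogen on a saturated chain carbon, seven bonds along the chain from an aromatic nitrogen, gives an at least 8.2-fold lower number from compound 1 to compound 3 (0.91 log units; beyond the scatter), which shows that among the compounds shown the chain makes a difference beyond the scatter, whereas the aromatic-carbon exchange does not. Compound 1 enters that step only as a limit, so the full size of the step stays unfixed: the limit of > 50000 nM in this assay, at which 1 of the 3 values shown sits.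

The compounds shown leave open whether a methylamino group, a hydroxyl or a chlorine on this aromatic carbon would read like methoxy and amino, and whether methoxy and amino would also stay level on a shorter chain. Also open, going by these compounds, is how a chain longer than that of compound 3, or a carboxylic acid in place of the hydroxyl, would read in this assay.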